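The source may report more compounds than this note shows. Statements on the series, on what has been measured and on what is new or still open speak of the compounds shown alone.

Working notes on the trimethoxybenzohydrazide series.

Of the compounds shown here, three have been measured in a functional assay on PC-3 cells (Homo sapiens) for antiproliferative activity, read by MTT assay, tested at 1 uM; on this read-out higher numbers stand for a stronger effect at the one concentration tested and lower numbers for a weaker effect. Compound 1 `COc1cc(C(=O)N/N=C/c2ccccc2F)cc(OC)c1OC` gives 70.6% in this assay. Compound 2 `COc1cc(C(=O)N/N=C/c2ccc(F)c(F)c2)cc(OC)c1OC` gives 35.1%, and compound 3 `COc1cc(C(=O)N/N=C/c2ccc(Cl)c(Cl)c2)cc(OC)c1OC` gives 13.5%. Compound 3 therefore stands lowest of the three numbers: the nearest neighbour is compound 2, and the step of a number 21.6 percentage points lower from compound 2 to compound 3 (beyond the scatter) was modest but beyond the scatter, while the step of a number 57.1 percentage points lower from compound 1 to compound 3 (beyond the scatter) was large. The step of a number 35.5 percentage points lower from compound 1 to compound 2 (beyond the scatter) was large as well.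

Compound 4 `COc1cc(C(=O)N/N=C/c2c(Cl)cccc2Cl)cc(OC)c1OC` has not yet been measured. It keeps every atom of compound 3 but joins them differently: 2,6-dichlorophenyl in place of 3,4-dichlorophenyl on a carbon with a double bond to nitrogen.

Within the data shown here, no measured step moves chlorine from one position to another on this ring, so the bearing of the existing steps is indirect. The steps from compound 1, carrying 2-fluorophenyl, to compound 2 and to compound 3 show that the 3,4-pattern with halogens reads weaker than a single halogen in the 2-position. On that reading, compound 4 is expected to recover part of the lost activity, with the step of a number 26.5 percentage points higher from compound 3 to compound 4 (beyond the scatter) expected to be upward and beyond the scatter. The estimate for compound 4 in this assay is 40%, expected to fall between 15% and 68%.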

Compound 4, a percentage reported as inhibition, at one concentration (the size of the read-out at that concentration, not a potency): 43%
For compound 4 the middle estimate is 3 percentage points below the measured one; measured number inside the range.
By their numbers in this assay, from the lowest: compound 3; then compounds 2 and 4 (each within the scatter of the next); then compound 1.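

In this assay, moving the same two chlorine atoms around the ring gives a number 29.5 percentage points higher from compound 3 to compound 4 (beyond the scatter) for 2,6-dichlorophenyl in place of 3,4-dichlorophenyl, so the reading at this position depends on how the halogens are arranged and not only on which halogen is present. Among these compounds, the earlier steps changed the halogen or its number along with the pattern, and this is the first step that holds the atoms fixed and changes only the joining. The new group still does not settle the ranking of the chlorine and fluorine patterns, since the change from 3,4-difluorophenyl gives a number 7.9 percentage points higher from compound 2 to compound 4 (within the scatter) and the change from 2-fluorophenyl gives a number 27.6 percentage points lower from compound 1 to compound 4 (beyond the scatter) and the 2-fluorophenyl compound stays apart. Nothing available explains these differences.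

Still open, going by these compounds, is whether fluorine in place of chlorine in the 2,6-dichlorophenyl group would move the reading toward that of compound 1. Also open, on these data alone, is how an unsubstituted phenyl, or a ring carrying a methoxy group or an amine in place of the halogens, would read at this position.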